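The source may report more compounds than this note shows. Statements on the series, on what has been measured and on what is new or still open speak of the compounds shown alone.

In a functional assay on HCT-116 cells (Homo sapiens) for antiproliferative activity, read by MTT assay, with a stated time of 72 h (on this read-out lower numbers stand for stronger inhibition and higher numbers for weaker inhibition), the values are these:
- Compound 1 `O=C(CCc1cccc2c1B(O)OC2)NC1CCCCC1` gives > 100000 nM as a limit of the assay
- Compound 2 `C#Cc1ccc(NC(=O)CCc2cccc3c2B(O)OC3)cc1` gives 45000 nM
- Compound 3 `C#Cc1cccc(NC(=O)CCc2cccc3c2B(O)OC3)c1` gives 3600 nM

Compound 3 has the lowest number of the two actual values, and compound 2 lies beyond the scatter from it, on the higher side. Compound 4 `O=C(CCc1cccc2c1B(O)OC2)Nc1cccc(-c2ccc(Cl)cc2)c1` has not yet been measured. It carries 4-chlorophenyl in place of ethynyl on an aromatic carbon, meta to a large group (4-chlorophenyl in place of ethynyl on an aromatic carbon). For the measured compounds named here, no measured step shows what such a change does, so only a modest move toward a lower number is expected in this assay, and a step within the scatter is also possible. The expected step is a 1.8-fold lower number from compound 3 to compound 4 (0.26 log units; within the scatter) in this estimate. The value of compound 4 is estimated at 2000 nM with a range from 300 nM to 15000 nM as expected.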

Compound 4, half-maximal inhibitory concentration: 380 nM
Compound 4: the middle estimate sits 5.3-fold (0.72 log units) above what was measured; the measured number falls inside the stated range.
By their numbers in this assay, from the lowest: compound 4; then compound 3; then compound 2. At a limit, above all of these: compound 1.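

In this assay the aromatic carbon that carries ethynyl in compound 3 accepts the much larger 4-chlorophenyl, which gives a 9.5-fold lower number from compound 3 to compound 4 (0.98 log units; beyond the scatter) and so shows that ethynyl is not needed at this position. This single change cannot establish a trend with group size. Nothing measured here gives a cause for the step.

The compounds shown leave open whether the ring or its chlorine goes with the lower number, as plain phenyl would tell. They also leave open how an amine or a carboxylic acid on that ring would read.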